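Naphthyl for bromo on the imidazopyrazine of compound 1

This account rests on a few compounds, and the source may have more. Where it says the series, first, only, none or still open, it means among the compounds named here.

Compound 1 `Brc1cn2ccnc2c(-c2ccc3ncn(C4CCCCC4)c3c2)n1` carries a bromo group on its core. Among the measured compounds shown here, in a functional assay on KM12 cells (Homo sapiens) for inhibition, read by sulforhodamine B assay, with a stated time of 48 h, tested at 10 uM (on this read-out higher numbers stand for more inhibition at the one concentration tested (going by the name of the read-out) and lower numbers for less inhibition), compound 1 gives 67.7%, the highest of the two numbers measured so far. Compound 2 `c1ccc(-c2cn3ccnc3c(-c3ccc4ncn(C5CCCCC5)c4c3)n2)cc1` carries a phenyl at the same position, and in this assay compound 2 gives 49%. For the measured compounds named here, the one measured step, a number 18.7 percentage points lower from compound 1 to compound 2 (beyond the scatter), therefore points downward when an aryl group replaces the bromo.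

Compound 3 `c1ccc2c(-c3cn4ccnc4c(-c4ccc5ncn(C6CCCCC6)c5c4)n3)cccc2c1` has not been measured. It differs from compound 1 as follows: naphthalen-1-yl in place of bromo on an aromatic carbon. Going by the values given here, the only step that bears on this change is the one from compound 1 to compound 2, where a phenyl entered in place of the bromo and the number fell by a modest amount beyond the scatter. Naphthalen-1-yl is a larger aryl group at the same position, so a drop of at least that order is expected for compound 3, with no measured pair to say whether the second ring pushes the number further down.

The expected step for compound 3 is a number 25.7 percentage points lower from compound 1 to compound 3 (beyond the scatter). Compound 3 is therefore estimated at 42%, with a range from 18% to 66%.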

Compound 3, a percentage reported as inhibition, at one concentration (the size of the read-out at that concentration, not a potency): 11.1%
Compound 3: the middle estimate sits 30.9 percentage points above what was measured; measured number below the stated range.
By their numbers in this assay, from the lowest: compound 3; then compound 2; then compound 1.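

In this assay, naphthalen-1-yl in place of bromo on the aromatic carbon of the core gives a number 56.6 percentage points lower from compound 1 to compound 3 (beyond the scatter) and stands as a large step, well past the modest fall seen with phenyl. Naphthalen-1-yl in place of phenyl adds a number 37.9 percentage points lower from compound 2 to compound 3 (beyond the scatter) on top of that, so the fall does not end once an aryl group has replaced the bromo, and the second aromatic ring of carbon only carries a large step of its own at this place. Across these three compounds the number drops in the order bromo, phenyl, naphthalen-1-yl, with no compound going against that order, but nothing at hand bears on why the number falls at this position.

The compounds shown leave open whether a non-aryl group at this place, such as an amine, a carboxylic acid or a short alkyl chain, would keep the number near that of compound 1 or lose it as the aryl groups do. Also open, going by these compounds, is whether naphthalen-2-yl, with the same two rings joined differently, would fall as far as compound 3 does.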